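A few compounds are considered here, and "the series" means these few. Any claim that something is new, unique, unknown or untested is made for them only; others in the source may bear on it.

Among the compounds with values here, compound 1 `COc1ccc(-c2ccc(-c3ccc(C(=N)N)cc3)s2)cc1` is one of three compounds measured in a functional assay on M14 cells (Homo sapiens) for inhibition, read by sulforhodamine B assay, with a stated time of 48 h (on this read-out lower numbers stand for stronger inhibition of growth and higher numbers for weaker inhibition of growth), where compound 1 gives 1410 nM. Compound 2 `N=C(N)c1ccc(-c2ccc(-c3cc(Cl)cc(Cl)c3)s2)cc1` gives 1540 nM in this assay, and compound 3 `N=C(N)c1ccc(-c2ccc(-c3ccccc3)s2)cc1F` gives 2120 nM. The number for compound 1 is the lowest of the three, though the gaps to compound 2 and to compound 3 both lie within the usual scatter, so the three compounds cannot be told apart on these data. Compound 4 `COc1ccc(-c2ccc(-c3ccc(C(=N)N)c(F)c3)s2)cc1` has not yet been measured. It differs from compound 1 by fluoro in place of hydrogen on an aromatic carbon. Compound 3 also carries a fluoro, and its value sits close to that of compound 1. Compound 4 is therefore expected to show a step of a 1.3-fold higher number from compound 1 to compound 4 (0.11 log units; within the scatter), not beyond the scatter, with an estimated value of 1800 nM between 900 nM and 3600 nM.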

Compound 4, concentration for 50% growth inhibition: 1900 nM
Beside the measured number, compound 4's estimate is 1.1-fold (0.02 log units) below it; the measured number falls inside the stated range.
By their numbers in this assay, from the lowest: compounds 1, 2, 4 and 3 (each within the scatter of the next).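

In this assay, fluoro in place of hydrogen on an aromatic carbon, ortho to a group of 3 heavy atoms, gives a 1.3-fold higher number from compound 1 to compound 4 (0.13 log units; within the scatter), so this small change at this position leaves the growth inhibition unresolved from that of compound 1. Adding a methoxy group with the fluoro present gives a 1.1-fold lower number from compound 3 to compound 4 (0.05 log units; within the scatter), which is likewise no resolved change. As far as these compounds go, whether an amine or a carboxylic acid at this position would move the number beyond the scatter stays open. No available evidence explains these small steps.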